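Benzyl swaps on the shared core: compound 4

This account rests on a few compounds, and the source may have more. Where it says the series, first, only, none or still open, it means among the compounds named here.

Within the data shown here, compound 2 `CC1(C)c2[nH]nc(NC(=O)c3ccccc3)c2CN1Cc1cccc(Br)c1` gives 940 nM in an assay on Sf21 cells for inhibition of high affinity nerve growth factor receptor (Homo sapiens), read by HTRF, with a stated time of 30 min, in the presence of a further agent that is not named here (on this read-out higher numbers stand for weaker inhibition and lower numbers for stronger inhibition), the second highest of the three numbers measured so far; compound 1 `CC1(C)c2[nH]nc(NC(=O)c3ccccc3)c2CN1Cc1ccccc1` stands nearest with 1240 nM, within the scatter, and compound 3 `CC1(C)c2[nH]nc(NC(=O)c3ccccc3)c2CN1Cc1cccc(F)c1F` furthest with 200 nM. The move to compound 4 `Cc1ccc(F)c(CN2Cc3c(NC(=O)c4ccccc4)n[nH]c3C2(C)C)c1` is 2-fluoro-5-methylphenyl in place of 3-bromophenyl on a saturated chain carbon bound to an amine nitrogen in a ring. Among the measured compounds shown here, two measured steps bear on it: a 4.7-fold lower number from compound 2 to compound 3 (0.67 log units; beyond the scatter) and a 6.2-fold lower number from compound 1 to compound 3 (0.79 log units; beyond the scatter), both gains on reaching 2,3-difluorophenyl, while a 1.3-fold lower number from compound 1 to compound 2 (0.12 log units; within the scatter) shows bromo alone doing little. The entering 2-fluoro-5-methylphenyl carries fluorine, as compound 3 does, but alongside a methyl rather than a second fluorine, so a gain smaller than that of compound 3 is expected. The expected step is therefore a modest one: a 2.4-fold lower number from compound 2 to compound 4 (0.37 log units; beyond the scatter). Compound 4 is estimated at 400 nM, with a range of 150 nM to 1000 nM.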

Compound 4, half-maximal inhibitory concentration: 880 nM
Compound 4: middle estimate off by 2.2-fold (0.34 log units), on the low side; the range from low to high includes it.
By their numbers in this assay, from the lowest: compound 3; then compounds 4, 2 and 1 (each within the scatter of the next).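

In this assay, a ring fluorine alone does not match compound 3: the 2-fluoro-5-methylphenyl group gives a 1.1-fold lower number from compound 2 to compound 4 (0.03 log units; within the scatter) and a 1.4-fold lower number from compound 1 to compound 4 (0.15 log units; within the scatter), while putting it in place of 2,3-difluorophenyl gives a 4.4-fold higher number from compound 3 to compound 4 (0.64 log units; beyond the scatter). Among these four compounds, the gain therefore appears only with 2,3-difluorophenyl, and compound 4, which also carries fluorine, goes against any rule covering all fluorinated benzyl groups. Nothing available accounts for this difference. Still open, from the compounds shown here alone, is how 2-fluorophenyl alone, without the methyl, would compare. Also open, going by these compounds, is whether 2,3-dichlorophenyl or 2,3-dimethoxyphenyl would keep the standing of compound 3.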